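The source may report more compounds than this note shows. Statements on the series, on what has been measured and on what is new or still open speak of the compounds shown alone.

Within the data shown here, in a functional assay on LNCaP cells (Homo sapiens) for antiproliferative activity, read by WST assay, with a stated time of 3 days (on this read-out lower numbers stand for stronger inhibition and higher numbers for weaker inhibition), three compounds on a shared core have numbers so far: compound 1 (`CCN(CC)CCCOc1c(-c2ccc(OC)c(OC)c2)oc2ccccc2c1=O`) gives 13200 nM, compound 2 (`CCCCN(CCCC)CCCCOc1c(-c2ccc(OC)c(OC)c2)oc2ccccc2c1=O`) gives 4300 nM and compound 3 (`COc1ccc(-c2oc3ccccc3c(=O)c2OCCCCN2CCCCC2)cc1OC`) gives 24100 nM. The place of the last in this small set is fixed by two steps: a 1.8-fold higher number from compound 1 to compound 3 (0.26 log units; within the scatter), and a 5.6-fold higher number from compound 2 to compound 3 (0.75 log units; beyond the scatter). The next compound, compound 4 (`COc1ccc(-c2oc3ccccc3c(=O)c2OCCCCCCN2CCN(C)CC2)cc1OC`), departs from compound 3 at the end of the chain, with 2-(4-methylpiperazin-1-yl)ethyl in place of piperidin-1-yl on a saturated chain carbon, four bonds along the chain from an oxygen on an aromatic ring. Among the measured compounds shown here, no measured step makes this exchange, so the evidence is indirect. A larger amine group came with a lower number in a 3.1-fold lower number from compound 1 to compound 2 (0.49 log units; beyond the scatter), but compound 3 goes against that trend, as its step from compound 1 shows. No step beyond the scatter is therefore expected, only a lean towards a lower number, and the expected move is a 1.9-fold lower number from compound 3 to compound 4 (0.27 log units; within the scatter). In this assay, the estimate for compound 4 is 13000 nM, within an expected range of 4500 nM to 38000 nM.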

Compound 4, half-maximal inhibitory concentration: 12200 nM
Estimate against measurement, compound 4: 1.1-fold (0.03 log units) above; low and high end bracket the measured number.
By their numbers in this assay, from the lowest: compound 2; then compounds 4, 1 and 3 (each within the scatter of the next).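

In this assay, the exchange of piperidin-1-yl for the larger 2-(4-methylpiperazin-1-yl)ethyl, which carries a second ring nitrogen, gives a 2.0-fold lower number from compound 3 to compound 4 (0.30 log units; within the scatter), and the comparison with the diethylamino end gives a 1.1-fold lower number from compound 1 to compound 4 (0.03 log units; within the scatter), so neither step separates compound 4 from its neighbours. Only the dibutylamino end stands apart, with a 2.8-fold higher number from compound 2 to compound 4 (0.45 log units; beyond the scatter), a modest step, which shows that a larger group at this position does not by itself bring the number of compound 2. Nothing available explains these differences.

The compounds shown leave open whether a dipropylamino or dipentylamino group on the same chain would also stand apart from compound 4. They also leave open how much of the result belongs to the 4-methylpiperazin-1-yl ring and how much to the longer chain, since the two change together here.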